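Adding a methoxycarbonyl group to a bromo-substituted analogue

This account rests on a few compounds, and the source may have more. Where it says the series, first, only, none or still open, it means among the compounds named here.

Compound 1, `Cc1ccccc1CSc1nc2ccccc2n1CC(=O)O`: 810 nM
Compound 2, `O=C(O)Cn1c(SCc2ccccc2Br)nc2ccccc21`: 580 nM

Of the compounds shown here, two have been measured in an assay on HEK293 cells for displacement of a labelled ligand from prostaglandin D2 receptor 2 (Homo sapiens); a lower number here means a stronger inhibitor, a higher number a weaker inhibitor. Compound 1 gives 810 nM and compound 2 gives 580 nM. Among the compounds with values here, the only measured step, a 1.4-fold lower number from compound 1 to compound 2 (0.15 log units; within the scatter), is within the scatter, so compound 2 holds the lower of the two numbers without standing apart from compound 1 in any meaningful way.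

Compound 3, `COC(=O)c1ccc(Br)c(CSc2nc3ccccc3n2CC(=O)O)c1`, is not yet measured. It differs from compound 2 by methoxycarbonyl in place of hydrogen on an aromatic carbon, the new group sitting on an aromatic carbon of a six-membered aromatic ring of carbon only. Within the data shown here, no measured step involves a methoxycarbonyl group or any change on that ring other than the swap from methyl to bromo, and that swap stayed within the scatter. There is therefore no basis in the measured numbers for expecting a shift in either direction, and the estimated step of a 1.1-fold lower number from compound 2 to compound 3 (0.02 log units; within the scatter) is expected to stay near zero, with a wide range to reflect the lack of a comparable precedent. For compound 3 the expected value in this assay is 550 nM, with a range from 150 nM to 2000 nM.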

Compound 3, half-maximal inhibitory concentration: 45 nM
Compound 3: the middle estimate sits 12-fold (1.09 log units) above what was measured; the measured number lies below the stated range.
By their numbers in this assay, from the lowest: compound 3; then compounds 2 and 1 (each within the scatter of the next).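

In this assay, methoxycarbonyl in place of hydrogen, on the aromatic carbon para to a bromo group and meta to a large group, gives a 13-fold lower number from compound 2 to compound 3 (1.11 log units; beyond the scatter). Within the data shown here, the only earlier change on this ring, bromo in place of methyl, gave a 1.4-fold lower number from compound 1 to compound 2 (0.15 log units; within the scatter), so this is the first step to lie beyond the scatter, and it shows that the number can respond strongly to what is attached at this position. The entering group has 4 heavy atoms, 2 hydrogen-bond acceptors, no hydrogen-bond donors and no net charge, but no measurement here explains why the number fell so far.

From the compounds shown here alone, it remains open whether this step is specific to methoxycarbonyl or would also appear with a carboxylic acid, an amide or a nitrile on the same carbon. Going by these compounds, it is also open whether methoxycarbonyl would give a similar step with methyl in place of bromo, since one step at one position cannot show whether the two groups act independently.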